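Amide to Urea on the Shared Core

A few compounds are considered here, and "the series" means these few. Any claim that something is new, unique, unknown or untested is made for them only; others in the source may bear on it.

Compound 1 `COc1cc(-c2nn(-c3cccc(NC(=O)c4cccc(C(F)(F)F)c4)c3)cc2-c2ccncc2)ccc1Cl` gives 968 nM in a functional assay on UO-31 cells (Homo sapiens) for inhibition, read by sulforhodamine B assay, with a stated time of 48 h; on this read-out higher numbers stand for weaker inhibition of growth and lower numbers for stronger inhibition of growth. Among the measured compounds shown here, compound 2 `COc1cc(-c2nn(-c3cccc(NC(=O)c4ccc(Cl)c(C(F)(F)F)c4)c3)cc2-c2ccncc2)ccc1Cl` gives 267 nM in this assay, the lowest of the two numbers measured so far, reached through the step of a 3.6-fold lower number from compound 1 to compound 2 (0.56 log units; beyond the scatter), the only measured step in this set. Compound 3 `COc1cc(-c2nn(-c3cccc(NC(=O)Nc4ccc(Cl)c(C(F)(F)F)c4)c3)cc2-c2ccncc2)ccc1Cl` has not yet been measured; it differs from compound 2 by (4-chloro-3-(trifluoromethyl)phenyl)amino in place of 4-chloro-3-(trifluoromethyl)phenyl on a carbonyl carbon. For the measured compounds named here, the one measured step, chloro in place of hydrogen on an aromatic carbon, changes a different part of the molecule and so does not bear on this move at the carbonyl carbon; no measured step speaks for or against it. With nothing in the data to pull the number strongly either way, the expected step is a 1.3-fold lower number from compound 2 to compound 3 (0.13 log units; within the scatter), a small shift downward that may well sit within the scatter. Compound 3 is therefore estimated at 200 nM in this assay, within a range from 60 nM to 700 nM.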

Compound 3, concentration for 50% growth inhibition: 865 nM
The estimate for compound 3 lay 4.3-fold (0.64 log units) below the measured number; measured number outside the range, above it.
By their numbers in this assay, from the lowest: compound 2; then compounds 3 and 1 (each within the scatter of the next).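

On the carbonyl carbon, placing (4-chloro-3-(trifluoromethyl)phenyl)amino where 4-chloro-3-(trifluoromethyl)phenyl stood is not a neutral exchange in this assay, since the change brings a 3.2-fold higher number from compound 2 to compound 3 (0.51 log units; beyond the scatter) and shows that this link between the carbonyl and the ring matters to the read-out. Measured against the amide without the chloro, the urea shows a 1.1-fold lower number from compound 1 to compound 3 (0.05 log units; within the scatter) and so keeps none of the lead held by the chlorinated amide. Nothing available explains why this position reacts to the change.

The compounds shown leave open whether the chloro moves the number on a urea as it does on the amide. They also leave open how a carbamate or a sulfonamide in this place would read.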